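A few compounds are considered here, and "the series" means these few. Any claim that something is new, unique, unknown or untested is made for them only; others in the source may bear on it.

Measured compounds:
compound 1 `CC(Oc1ccc(Oc2ccc(F)cc2)cc1)C(=O)Cn1nnc(-c2ccccc2)n1`, 24 nM
compound 2 `CC(Oc1ccc(Oc2ccc(C(F)(F)F)cc2)cc1)C(=O)Cn1nnc(-c2ccccc2)n1`, 160 nM
compound 3 `CC(Oc1ccc(-c2ccccc2)cc1)C(=O)Cn1nnc(-c2ccccc2)n1`, 15 nM

All three were measured in an assay on microsomes from brain for inhibition of Fatty-acid amide hydrolase 1 (Rattus norvegicus), read by fluorescence and HPLC, with a stated time of 60 min; on this read-out higher numbers stand for weaker inhibition and lower numbers for stronger inhibition. Compound 3 gives the lowest number of the three, 15 nM, although the gap to compound 1 is within the scatter and only compound 2 stands clearly apart, as shown by an 11-fold lower number from compound 2 to compound 3 (1.03 log units; beyond the scatter). The steps among the measured compounds all concern the outer ring at one end of the shared core: a 6.7-fold higher number from compound 1 to compound 2 (0.82 log units; beyond the scatter) and a 1.6-fold lower number from compound 1 to compound 3 (0.20 log units; within the scatter).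

Compound 4 `CC(Oc1ccc(-c2ccccc2)cc1)C(=O)Cn1nnc(-c2ccc(C(=O)O)cc2)n1` differs from compound 3 at the other end of the molecule: carboxy in place of hydrogen on an aromatic carbon. Going by the values given here, none of the measured steps touches this position, so they give no direct reading on the change; they only show that compound 3 is a good starting point. The estimate for compound 4 in this assay therefore rests on the expectation that attaching a carboxy group, with its hydrogen-bond donor and acceptor, to a ring that is otherwise untouched in the series gives a modest shift, expected as a 5.3-fold higher number from compound 3 to compound 4 (0.73 log units; beyond the scatter). Compound 4 is thus expected to give about 80 nM, with a range from 15 nM to 500 nM.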

Compound 4, half-maximal inhibitory concentration: 83 nM
For compound 4 the middle estimate is 1.0-fold (0.02 log units) below the measured one; the range from low to high includes it.
By their numbers in this assay, from the lowest: compounds 3 and 1 (each within the scatter of the next); then compounds 4 and 2 (each within the scatter of the next).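

In this assay, going by these compounds alone, the result gives the first reading on the phenyl ring at the far end of the molecule from the outer ring varied in compounds 1, 2 and 3: putting carboxy on an aromatic carbon there, para to a large group, gives a 5.5-fold higher number from compound 3 to compound 4 (0.74 log units; beyond the scatter) and so lies outside the usual scatter. The position is therefore not indifferent to substitution, although the change from phenyl to 4-carboxyphenyl still leaves compound 4 at 83 nM, so inhibition remains measurable in the nanomolar range. Nothing available accounts for the size of this step, and its cause stays unassigned.

The compounds shown leave open whether a methyl ester, a primary amide or a hydroxymethyl group at the same place would give a step of similar size, or whether the step belongs to the carboxylic acid alone. They also leave open how a carboxylic acid would read at the other carbons of this ring, and whether the same step would appear with the 4-fluorophenoxy group of compound 1 at the opposite end.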